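This account rests on a few compounds, and the source may have more. Where it says the series, first, only, none or still open, it means among the compounds named here.

Of the compounds shown here, three have numbers so far in a functional assay on MDA-MB-231 cells (Homo sapiens) for antiproliferative activity, read by sulforhodamine B assay, with a stated time of 72 h; on this read-out lower numbers stand for stronger inhibition and higher numbers for weaker inhibition. Compound 1 (`CC(=O)Nc1ccc(S(=O)(=O)Nc2cc(SCC(=O)N[C@@H](CC(C)C)B(O)O)c(O)c3ccccc23)cc1`) gives 4450 nM, compound 2 (`Cc1ccc(S(=O)(=O)Nc2cc(SCCC(=O)N[C@@H](CC(C)C)B(O)O)c(O)c3ccccc23)cc1`) gives 6150 nM, and compound 3 (`CC(C)C[C@H](NC(=O)CCSc1cc(NS(=O)(=O)c2cccs2)c2ccccc2c1O)B(O)O`) gives 4450 nM. Compound 3 therefore stands level with compound 1, and the three values lie within the scatter of one another.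

The next compound is compound 4 (`CC(=O)Nc1ccc(S(=O)(=O)Nc2cc(SCCC(=O)N[C@@H](CC(C)C)B(O)O)c(O)c3ccccc23)cc1`), which has 4-acetamidophenyl in place of thiophen-2-yl on a sulfonyl sulfur.

Going by the values given here, only one measured step bears directly on this place, the exchange of 4-methylphenyl for thiophen-2-yl: a 1.4-fold lower number from compound 2 to compound 3 (0.14 log units; within the scatter). The entering 4-acetamidophenyl group is also present in compound 1, at 4450 nM, although that compound differs from compound 4 elsewhere in the structure. Among the compounds with values here, no measured pair isolates the effect of 4-acetamidophenyl, so this evidence is thin. Neither observation points to a change beyond the scatter in this assay, and no clear direction is expected, only a slight drift to a higher number at most. The expected step is small: a 1.1-fold higher number from compound 3 to compound 4 (0.03 log units; within the scatter). For compound 4 the estimated value is 4800 nM, with an expected range of 2400 nM to 9500 nM.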

Compound 4, half-maximal inhibitory concentration: 2120 nM
Estimate against measurement, compound 4: 2.3-fold (0.35 log units) above, outside the stated range (below it).
By their numbers in this assay, from the lowest: compound 4; then compounds 1, 3 and 2 (each within the scatter of the next).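

In this assay, this position on the sulfonyl sulfur now gives a step beyond the scatter: 4-acetamidophenyl in place of thiophen-2-yl gives a 2.1-fold lower number from compound 3 to compound 4 (0.32 log units; beyond the scatter), and acetamido in place of methyl on an aromatic carbon gives a 2.9-fold lower number from compound 2 to compound 4 (0.46 log units; beyond the scatter), whereas the earlier exchange of 4-methylphenyl for thiophen-2-yl stayed within the scatter, at a 1.4-fold lower number from compound 2 to compound 3 (0.14 log units; within the scatter). The 4-acetamidophenyl group alone does not set the level, since with that group held constant, a group of 12 heavy atoms in place of a group of 11 heavy atoms, on a saturated chain carbon bound to a sulfur, gives a 2.1-fold lower number from compound 1 to compound 4 (0.32 log units; beyond the scatter). No measurement here accounts for either change.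

The compounds shown leave open whether the gain belongs to the acetamido group itself or would persist with an amine or a carboxylic acid at the same place on the phenyl ring. They also leave open whether a longer chain on the sulfur would extend the step seen from the shorter chain of compound 1 or reverse it.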